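The source may hold more compounds than are shown below. What is called first, only, known or untested is meant among the compounds shown, and "the series" means these compounds.

Compound 1, `COCc1ccccc1Cc1cnc(N)nc1N`: in an assay for inhibition of Dihydrofolate reductase (Gallus gallus) (on this read-out lower numbers stand for stronger inhibition and higher numbers for weaker inhibition), compound 1 gives 39800 nM.
Compound 2, `C=CCOc1ccccc1Cc1cnc(N)nc1N`: in this assay compound 2 gives 21400 nM.
Compound 3, `Nc1ncc(Cc2ccccc2Cl)c(N)n1`: in this assay compound 3 gives 17400 nM.

Compound 3 is separated from compound 1 by a step beyond the scatter, a 2.3-fold lower number from compound 1 to compound 3 (0.36 log units; beyond the scatter), while compound 2 sits within the scatter of compound 3, as a 1.2-fold lower number from compound 2 to compound 3 (0.09 log units; within the scatter) shows. The unmeasured compound 4, `CCCCCCOc1ccccc1Cc1cnc(N)nc1N`, differs from compound 3 by hexyloxy in place of chloro on an aromatic carbon. Going by the values given here, two measured steps bear on this change: the exchange of an alkoxy group for chloro, a 1.2-fold lower number from compound 2 to compound 3 (0.09 log units; within the scatter), was within the scatter, and the exchange of methoxymethyl for chloro, a 2.3-fold lower number from compound 1 to compound 3 (0.36 log units; beyond the scatter), was only modest. Compound 4 is therefore expected to give a number close to that of compound 3, with a step of a 1.1-fold higher number from compound 3 to compound 4 (0.06 log units; within the scatter) that is not expected to exceed the scatter. The estimate for compound 4 in this assay is 20000 nM, within the range 8000 nM to 50000 nM.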

Compound 4, inhibition constant: 7940 nM
For compound 4 the middle estimate is 2.5-fold (0.40 log units) above the measured one; the measured number lies below the stated range.
By their numbers in this assay, from the lowest: compound 4; then compounds 3, 2 and 1 (each within the scatter of the next, the first and the last beyond it).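

Hexyloxy on this aromatic carbon is the first group to move the number clearly away from chloro: in this assay the change gives a 2.2-fold lower number from compound 3 to compound 4 (0.34 log units; beyond the scatter). Allyloxy had stayed within the scatter of chloro, yet the longer ether, with pentyl in place of vinyl, gives a 2.7-fold lower number from compound 2 to compound 4 (0.43 log units; beyond the scatter). The widest gap is a 5.0-fold lower number from compound 1 to compound 4 (0.70 log units; beyond the scatter), and compound 4 alone has steps to all the others that lie beyond the scatter.

As far as these compounds go, whether the number keeps falling with a longer chain such as octyloxy, or with an amine at the chain end, stays open. Nothing at hand accounts for the lower number.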